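Compound 4: a larger group in place of hydroxy

A few compounds are considered here, and "the series" means these few. Any claim that something is new, unique, unknown or untested is made for them only; others in the source may bear on it.

In an ADME assay on NCM460 cells (Homo sapiens) for cytotoxicity, read by CCK-8 assay, with a stated time of 48 h (on this read-out lower numbers stand for stronger inhibition and higher numbers for weaker inhibition), compound 3 (`COc1ccc(/C=C\c2cc(OC)c(OC)c(OC)c2)cc1OCc1ccc(CO)cc1`) gives > 50000 nM, which is a limit of the assay and not a number. Compound 1 (`COc1ccc(/C=C\c2cc(OC)c(OC)c(OC)c2)cc1OCc1ccc(CN[C@H](C(=O)O)[C@H](C)O)cc1`) gives > 50000 nM, which is also a limit. Among the compounds with values here, compound 2 (`COc1ccc(/C=C\c2cc(OC)c(OC)c(OC)c2)cc1OCc1ccc(CN2CCCCC2C(=O)NCCNC(=O)OC(C)(C)C)cc1`), which carries a different group, is the only one with a true number, 28000 nM. Compound 3 therefore stands with the majority, at the limit of > 50000 nM in this assay, at which 2 of the 3 values shown sit.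

Compound 4 (`COc1ccc(/C=C\c2cc(OC)c(OC)c(OC)c2)cc1OCc1ccc(CN[C@H](C(=O)O)[C@@H](C)O)cc1`) keeps the shared core but changes one group: (1-carboxy-2-hydroxypropyl)amino in place of hydroxy on a saturated chain carbon bound to an aromatic carbon. Within the data shown here, the group that enters is the one compound 1 already carries, and the two compounds differ only in the spatial arrangement at a defined stereocentre.

Among the measured compounds shown here, one measured step bears on this change: a step that the two limits leave unreadable from compound 1 to compound 3. It is the same exchange run in the opposite direction, but it gives no size to carry over. Compound 1, with the entering group in place, reads > 50000 nM, again a limit, so no step beyond the scatter is expected in this assay, and no direction can be favoured. The expected change is a step that the limit leaves unreadable from compound 3 to compound 4. Compound 4 is estimated at 60000 nM, with an expected range from 30000 nM to 120000 nM, and the assay will most likely report only a limit.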

Compound 4, half-maximal inhibitory concentration: > 50000 nM
Compound 4: no number, only a limit (the forecaster's own chance of this, stated with the estimate: 80%); the middle value is on the limit's open side.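

Compound 4 gives only a limit, so neither its step from compound 3 nor its step from compound 1 can be read: the limit of > 50000 nM in this assay, at which 3 of the 4 values shown sit.

The compounds shown leave open whether, in this assay, the change of configuration between compound 1 and compound 4 or the exchange of hydroxy for (1-carboxy-2-hydroxypropyl)amino between compound 3 and compound 4 has any effect.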